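A Methoxy Step Tested on a Second Core

This account rests on a few compounds, and the source may have more. Where it says the series, first, only, none or still open, it means among the compounds named here.

Compound 1 `CCc1ccc2nc(-c3ccc(-n4nnc5ccccc54)c(C)c3)sc2c1` is one of three measured compounds. In a functional assay on Ca9-22 cells (Homo sapiens) for inhibition, read by wound healing assay, with stated times of 2 h and 16 h, tested at 2 uM (on this read-out higher numbers stand for more inhibition at the one concentration tested (going by the name of the read-out) and lower numbers for less inhibition), compound 1 gives 70.1%. Compound 2 `CCc1ccc2nc(-c3ccc(-n4nnc5cc(OC)ccc54)c(C)c3)sc2c1` differs from it in a single change, (methoxy in place of hydrogen on an aromatic carbon), and in this assay compound 2 gives 31.1%; the step of a number 39 percentage points lower from compound 1 to compound 2 (beyond the scatter). Compound 3 `COc1ccc2nc(-c3ccc(-n4nnc5ccccc54)cc3)sc2c1` rests on a different core, and the difference between the two cores is not broken down here. In this assay compound 3 gives 68.7%, a number within the scatter of compound 1 and well beyond the scatter of compound 2.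

Compound 4 `COc1ccc2c(c1)nnn2-c1ccc(-c2nc3ccc(OC)cc3s2)cc1` has not yet been measured. Within the data shown here, it arises from compound 3 by methoxy in place of hydrogen on an aromatic carbon, which is the same change as the one from compound 1 to compound 2, with the new group sitting at the same kind of place. The change thus occurs twice among these compounds, once with a measurement behind it. The expectation for compound 4 rests on that one measured step: because a number 39 percentage points lower from compound 1 to compound 2 (beyond the scatter) was large, a drop is expected on the second core as well, though a single example cannot show whether the size carries over to a core that itself bears a methoxy group. The estimated step of a number 33.7 percentage points lower from compound 3 to compound 4 (beyond the scatter) is therefore expected to be downward. Compound 4 is estimated at 35% in this assay, expected to fall between 15% and 55%.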

Compound 4, a percentage reported as inhibition, at one concentration (the size of the read-out at that concentration, not a potency): 51.7%
Estimate against measurement, compound 4: 16.7 percentage points below; the measured number falls inside the stated range.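

In this assay, methoxy in place of hydrogen on an aromatic carbon lowers the number on the second core as well, with a number 17 percentage points lower from compound 3 to compound 4 (beyond the scatter) standing beside the larger step on the first, so across these two cores the direction of the change carries over. The size does not carry over, and the same change costs clearly less on the core of compound 3 than on the core of compound 1: the same change on two cores in this assay, a number 39 percentage points lower (beyond the scatter) from compound 1 to compound 2 and a number 17 percentage points lower (beyond the scatter) from compound 3 to compound 4, 22 percentage points apart, beyond the scatter of two such steps. Among these compounds, this does not show which of the differences between the two cores accounts for the gap, and with only two pairs it gives no rule for how the step would behave on any further core.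

The compounds shown leave open whether a hydroxyl group, an amine or a longer chain such as ethoxy in the same place would lower the number as methoxy does, or whether the drop belongs to methoxy alone. They also leave open whether the two steps would keep their direction and their gap at other concentrations, as every number here comes from a single concentration in one assay.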